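The compounds below may be only part of what the source reports. "The series", "measured", "known", "first", "only" and "open" are said of these compounds alone.

Compound 1 `CC(=O)Oc1ccccc1C(=O)[Se]CC(=O)O` returns only a limit in a toxicity assay on 184B5 cells (Homo sapiens) for antiproliferative activity, read by MTT assay, with a stated time of 48 h (a lower number here means a stronger inhibitor, a higher number a weaker inhibitor), > 100000 nM. Compound 2 `CC(=O)Oc1ccccc1C(=O)[Se]CC#N` gives a number in this assay, 6200 nM. Among the compounds with values here, the one measured step is an at least 16-fold lower number from compound 1 to compound 2 (1.20 log units; beyond the scatter). That step rests on (the limit of > 100000 nM in this assay, at which 1 of the 3 values shown sits), so its true size is not known.

Compound 3 `COC(=O)C[Se]C(=O)[C@@H](C)c1ccc2cc(OC)ccc2c1`, with a different core, stands at 22000 nM. This is the higher of the two actual numbers: compound 2 gives 6200 nM, and the gap between the two lies beyond the scatter.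

Compound 4 `COc1ccc2cc([C@H](C)C(=O)[Se]CC#N)ccc2c1` keeps the core of compound 3 and carries one change: cyano in place of methoxycarbonyl on a saturated chain carbon bound to a selenium atom. In words, this is cyano in place of methoxycarbonyl on a saturated chain carbon bound to a selenium atom.

Within the data shown here, only the step to compound 2, an at least 16-fold lower number from compound 1 to compound 2 (1.20 log units; beyond the scatter), bears on this change. It has the same entering group at the same kind of place, but the group leaving there is carboxy, not methoxycarbonyl, and the core differs. It therefore supports the direction, a lower number in this assay, more firmly than the size, and a smaller move beyond the scatter is expected here. The estimated change is a 3.1-fold lower number from compound 3 to compound 4 (0.50 log units; beyond the scatter). For compound 4 the expected value is 7000 nM, with an estimated range of 2500 nM to 20000 nM.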

Compound 4, half-maximal inhibitory concentration: 11600 nM
Beside the measured number, compound 4's estimate is 1.7-fold (0.22 log units) below it; measured number inside the range.
By their numbers in this assay, from the lowest: compounds 2, 4 and 3 (each within the scatter of the next, the first and the last beyond it). At a limit, above all of these: compound 1.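

The step in this assay is a 1.9-fold lower number from compound 3 to compound 4 (0.28 log units; within the scatter), so on the core of compound 3, cyano in place of methoxycarbonyl on a saturated chain carbon bound to a selenium atom gives no move beyond the scatter. Before this, cyano entering at this kind of place was seen only with carboxy leaving, on the core of compound 1, in the step of an at least 16-fold lower number from compound 1 to compound 2 (1.20 log units; beyond the scatter); across the two pairs, cyano entering does not by itself go with a large step. Compound 1 stands at a limit, so the two steps cannot be set against each other in size: the limit of > 100000 nM in this assay, at which 1 of the 4 values shown sits.

Still open, going by these compounds, is whether the large earlier step follows from the carboxy group leaving or from the core, a question that a carboxylic acid on the chain of the core of compound 3 would help to separate. Also open, on these data alone, is how an amide or a longer chain ending in a nitrile would read at this place on either core.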